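Swapping the aryl group on the core of compound 1

A few compounds are considered here, and "the series" means these few. Any claim that something is new, unique, unknown or untested is made for them only; others in the source may bear on it.

Measured so far:
compound 1 `C/C(=N\NC(=O)COc1cccc2ccccc12)c1cccc([N+](=O)[O-])c1` gives 20 ug/mL
compound 2 `O=C(COc1cccc2ccccc12)N/N=C/C=C/c1ccccc1` gives 100 ug/mL
compound 3 `COc1ccc(/C=N/NC(=O)COc2cccc3ccccc23)cc1OC` gives >= 20 ug/mL

These three compounds were tested in an ADME assay on HEL cells (Homo sapiens) for cytotoxicity; on this read-out lower numbers stand for higher toxicity in this test and higher numbers for lower toxicity in this test. Compound 1 has the lowest of the two numbers shown; compound 2 sits a good deal higher, and that gap lies beyond the scatter of repeated measurements. For compound 3 the result is a limit of the assay and not a number, and it sits at the limit of >= 20 ug/mL in this assay, at which 1 of the 3 values shown sits.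

Compound 4 `C/C(=N\NC(=O)COc1cccc2ccccc12)c1ccc(Cl)cc1` is not yet measured. It differs from compound 1 in one place: 4-chlorophenyl in place of 3-nitrophenyl on a carbon with a double bond to nitrogen. The rest of the core of compound 1 is kept unchanged.

For the measured compounds named here, no step between measured compounds isolates this kind of change, so there is nothing to lean on beyond the value of compound 1 itself. Compound 4 is expected to stay close to compound 1, with a step of a 1.5-fold higher number from compound 1 to compound 4 (0.18 log units; within the scatter) that is small and within the scatter or slightly toward lower toxicity. Compound 4 is therefore estimated at 30 ug/mL, with a likely range from 10 ug/mL to 100 ug/mL.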

Compound 4, minimum cytotoxic concentration: >= 4 ug/mL
Compound 4 ended at the assay's limit (the forecaster's own chance of this, stated with the estimate: 40%); the middle value lies beyond the limit too.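

In this assay compound 4 gives >= 4 ug/mL, which is a limit of the assay and not a number. The step between compound 1 and compound 4 therefore cannot be read. The compounds shown leave open whether 4-chlorophenyl in place of 3-nitrophenyl changes the read-out, and in which direction.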